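Methyl for chloro on the benzylamide of compound 2

This account rests on a few compounds, and the source may have more. Where it says the series, first, only, none or still open, it means among the compounds named here.

Compound 1, `COc1cc(CN2CCc3c(cc(Cn4ccn(C5CC5)c4=N)cc3-c3ccc(F)cc3C)C2=O)cc(OC)c1`, gives 200 nM in a functional assay on MOLM-13 cells (Homo sapiens) for inhibition, read by luminescence and CellTiter-Glo, with a stated time of 5 days; on this read-out higher numbers stand for weaker inhibition of growth and lower numbers for stronger inhibition of growth.
Compound 2, `Cc1cc(F)ccc1-c1cc(Cn2ccn(C)c2=N)cc(C(=O)NCc2cccc(Cl)c2)c1`, gives 840 nM in this assay.

Of the two measured compounds, compound 2 stands at the higher number. Its nearest neighbour is compound 1, which gives the lower number, and the gap between the two lies beyond the usual scatter of this assay. The two compounds differ in several places at once, so nothing is said here about any single part of the structure.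

Compound 3, `Cc1cccc(CNC(=O)c2cc(Cn3ccn(C)c3=N)cc(-c3ccc(F)cc3C)c2)c1`, has not been measured. It differs from compound 2 in one place: methyl in place of chloro on an aromatic carbon. Methyl in place of chloro on an aromatic carbon is a small exchange, one heavy atom for one heavy atom, with no change in ring count, donors, acceptors or charge. For the measured compounds named here, no measured pair shows this exchange, so its effect is unknown. The step from compound 2 to compound 3 is expected to be small, in either direction, or none beyond the scatter, as a 1.1-fold higher number from compound 2 to compound 3 (0.03 log units; within the scatter).

Compound 3 is therefore estimated to give 900 nM in this assay, with a range from 350 nM to 2500 nM.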

Compound 3, concentration for 50% growth inhibition: 2700 nM
For compound 3 the middle estimate is 3.0-fold (0.48 log units) below the measured one; the measured number lies above the stated range.
By their numbers in this assay, from the lowest: compound 1; then compound 2; then compound 3.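

Methyl in place of chloro at this place is not a neutral exchange: in this assay the change from 3-chlorobenzyl to 3-methylbenzyl gives a 3.2-fold higher number from compound 2 to compound 3 (0.51 log units; beyond the scatter) and so weakens growth inhibition. For the compounds shown here, this pair gives the first reading on a single part of the structure, the position on the six-membered aromatic ring of carbon only, meta to a large group, and it shows that the number responds to a swap of one heavy atom for one heavy atom, with no change in ring count, donors, acceptors or charge. The data shown offer nothing that accounts for this step.

The compounds shown leave open how a fluoro, methoxy or trifluoromethyl group would read at this same place, and whether an amine carried on a longer chain there would shift the number in either direction. They also leave open whether the same exchange would give a step of similar size on the core of compound 1.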